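Propyl for Phenyl on a Fused Lactam Core

The source may hold more compounds than are shown below. What is called first, only, known or untested is meant among the compounds shown, and "the series" means these compounds.

Three compounds with a shared core were measured in an ADME assay on the whole organism for inhibition, with Oryza sativa as the target, with a stated time of 7 days; a higher number here means a weaker inhibitor, a lower number a stronger inhibitor. Compound 1 `CCCC1Oc2ccc(F)cc2N(O)C1=O` gives 337000 nM. Compound 2 `O=C1C(c2ccccc2)Oc2ccc(F)cc2N1O` gives 1240000 nM, and compound 3 `O=C1C(c2ccccc2)Oc2c(Cl)cccc2N1O` gives 384000 nM. The difference between the core of compound 2 and the core of compound 3 is not broken down here.

Among the measured compounds shown here, the one counted step runs from compound 2 to compound 1, (propyl in place of phenyl on a saturated ring carbon), and its size is a 3.7-fold lower number from compound 2 to compound 1 (0.57 log units; beyond the scatter). Compound 4 `CCCC1Oc2c(Cl)cccc2N(O)C1=O` has not been measured; it differs from compound 3 by propyl in place of phenyl on a saturated ring carbon. The two place lines match word for word, so this is the same change made a second time, on a core whose difference from that of compound 2 is not broken down.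

Because the earlier step was a 3.7-fold lower number from compound 2 to compound 1 (0.57 log units; beyond the scatter), compound 4 is expected to show a lower number than compound 3, with the expected step of a 3.0-fold lower number from compound 3 to compound 4 (0.47 log units; beyond the scatter). Since the cores differ in a way not counted here, the expectation is held loosely. The estimate for compound 4 in this assay is 130000 nM, between 50000 nM and 400000 nM.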

Compound 4, half-maximal inhibitory concentration: 614000 nM
For compound 4 the middle estimate is 4.7-fold (0.67 log units) below the measured one, outside the stated range (above it).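

In this assay propyl in place of phenyl on a saturated ring carbon gives a 1.6-fold higher number from compound 3 to compound 4 (0.20 log units; within the scatter) and so leaves compound 3 and compound 4 indistinguishable. The lower number that this change brought on the core of compound 2 did not carry over to the core of compound 3, and the change cannot be assumed to transfer between these two cores: the same change on two cores in this assay, a 3.7-fold lower number (0.57 log units; beyond the scatter) from compound 2 to compound 1 and a 1.6-fold higher number (0.20 log units; within the scatter) from compound 3 to compound 4, 5.9-fold (0.77 log units) apart, beyond the scatter of two such steps

What this does not show is which difference between the cores decides the outcome, and two pairs give no rule for any further core in the series. From the compounds shown here alone, it remains open how a longer chain, such as a pentyl, would read on either core in place of propyl on that saturated ring carbon. Going by these compounds, it is equally open whether a chain ending in an amine or a carboxylic acid would follow the result on the core of compound 2, that on the core of compound 3, or neither.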